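The source may report more compounds than this note shows. Statements on the series, on what has been measured and on what is new or still open speak of the compounds shown alone.

Measured compounds:
compound 1, `COc1ccc(-c2ccnc(C(=O)Nc3ccc(Oc4ccnc5cc(OCCCN6CCCCC6)c(OC)cc45)c(F)c3)c2)cc1`, 570 nM
compound 2, `COc1cc2c(Oc3ccc(NC(=O)c4cc(-c5ccccc5)ccn4)cc3F)ccnc2cc1OCCCN1CCCC1`, 210 nM
compound 3, `COc1ccc(-c2ccnc(C(=O)Nc3ccc(Oc4ccnc5cc(OCCCN6CCCC6)c(OC)cc45)c(F)c3)c2)cc1`, 150 nM

All three were tested in a functional assay on MKN-45 cells (Homo sapiens) for cytotoxicity, read by MTT assay, with a stated time of 72 h; a higher number here means a weaker inhibitor, a lower number a stronger inhibitor. Compound 3 gives 150 nM, compound 2 gives 210 nM, and compound 1 gives 570 nM. Compound 1 and compound 3 differ in one place only: piperidin-1-yl in place of pyrrolidin-1-yl on a saturated chain carbon, three bonds along the chain from an oxygen on an aromatic ring. That change brought a 3.8-fold higher number from compound 3 to compound 1 (0.58 log units; beyond the scatter). Compound 2 and compound 3 differ in their cores in one spot: hydrogen in place of methoxy on an aromatic carbon. The step of a 1.4-fold lower number from compound 2 to compound 3 (0.15 log units; within the scatter) lies within the usual scatter, so the two cores behave much alike in this assay .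

Compound 4, `COc1cc2c(Oc3ccc(NC(=O)c4cc(-c5ccccc5)ccn4)cc3F)ccnc2cc1OCCCN1CCCCC1`, has not yet been measured. It comes from compound 2 by piperidin-1-yl in place of pyrrolidin-1-yl on a saturated chain carbon, three bonds along the chain from an oxygen on an aromatic ring. The place of this change is the same, word for word, as the place of the change from compound 3 to compound 1, so this is the same change made on a core that carries hydrogen where the other carries methoxy. The expectation for compound 4 rests on the pair of compound 3 and compound 1, because a 3.8-fold higher number from compound 3 to compound 1 (0.58 log units; beyond the scatter) shows what this change did on the methoxy-bearing core, and on the closeness of compound 2 to compound 3 shown by a 1.4-fold lower number from compound 2 to compound 3 (0.15 log units; within the scatter). Going by the values given here, only one earlier example of the change exists, so its size on the new core is uncertain. From compound 2 to compound 4 a step of a 3.3-fold higher number from compound 2 to compound 4 (0.52 log units; beyond the scatter) is expected. Compound 4 is therefore estimated at 700 nM, with a likely range from 300 nM to 1800 nM.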

Compound 4, half-maximal inhibitory concentration: 270 nM
The estimate for compound 4 lay 2.6-fold (0.41 log units) above the measured number; the measured number lies below the stated range.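

Carried to the core of compound 2, the swap of pyrrolidin-1-yl for piperidin-1-yl gives, in this assay, a 1.3-fold higher number from compound 2 to compound 4 (0.11 log units; within the scatter), so the step seen on the methoxy-bearing core did not carry over at its earlier size: the same change on two cores in this assay, a 3.8-fold higher number (0.58 log units; beyond the scatter) from compound 3 to compound 1 and a 1.3-fold higher number (0.11 log units; within the scatter) from compound 2 to compound 4, 3.0-fold (0.47 log units) apart, beyond the scatter of two such steps

The same four compounds can be read the other way round: with piperidin-1-yl in place, hydrogen in place of methoxy gives a 2.1-fold lower number from compound 1 to compound 4 (0.32 log units; beyond the scatter), and the effect of this change also differs with the amine ring on the chain: the same change on two cores in this assay, a 1.4-fold lower number (0.15 log units; within the scatter) from compound 2 to compound 3 and a 2.1-fold higher number (0.32 log units; beyond the scatter) from compound 4 to compound 1, 3.0-fold (0.47 log units) apart, beyond the scatter of two such steps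

This shows that, among these four compounds, the two changes do not simply add up, so a step measured on one core is a poor guide to the other, but it rests on a single set of four compounds and shows neither why the steps differ nor whether this holds for any other core.

The compounds shown leave open how a morpholin-4-yl group, a dimethylamino group or a piperazin-1-yl group in place of pyrrolidin-1-yl would behave on each core, and what a longer chain would do. They also leave open whether a chlorine or a hydroxy group in place of methoxy would change the size of the ring swap in the same way.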